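The source may hold more compounds than are shown below. What is called first, only, known or untested is meant among the compounds shown, and "the series" means these compounds.

Measured so far:
- compound 1 `O=C1CSC(c2cccc(F)c2)N1CCN1CCCCC1`: 100%
- compound 2 `O=C1CSC(c2ccc(Cl)cc2)N1CCN1CCCCC1`: 90%

Both compounds share one core and differ only in the aryl group attached to it. In an ADME assay on Vero cells (Chlorocebus sabaeus) for cytotoxicity, read by neutral red uptake, tested at 12.3 ug/mL (on this read-out higher numbers stand for a weaker effect at the one concentration tested and lower numbers for a stronger effect), compound 1 gives 100% and compound 2 gives 90%. Within the data shown here, the single measured step, a number 10 percentage points lower from compound 1 to compound 2 (within the scatter), changes one halogen-bearing phenyl for another; its size lies within the scatter, so on the numbers at hand compound 2 cannot be told apart from compound 1.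

Compound 3 `O=C1CSC(c2ccc([N+](=O)[O-])cc2)N1CCN1CCCCC1` is the next compound in this series. It differs from compound 2 by nitro in place of chloro on an aromatic carbon.

Among the measured compounds shown here, the only measured step that bears on this change is a number 10 percentage points lower from compound 1 to compound 2 (within the scatter), and it concerns a different exchange: one halogen for another, not a halogen for nitro. Nothing measured here shows what a nitro group does in this assay. With only a within-scatter step as a guide, the expectation is for compound 3 a step of a number 2 percentage points higher from compound 2 to compound 3 (within the scatter), that is, no step beyond the scatter. The estimate for compound 3 in this assay is 92%, with a range from 72% to 100%.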

Compound 3, a percentage reported as activity, at one concentration (the size of the read-out at that concentration, not a potency): 100%
Compound 3: middle estimate off by 8 percentage points, on the low side; the range from low to high includes it.
By their numbers in this assay, from the lowest: compounds 2, 1 and 3 (each within the scatter of the next).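

Nitro in place of chloro on this aromatic carbon, para to a large group, gives a number 10 percentage points higher from compound 2 to compound 3 (within the scatter) in this assay, so compound 2 and compound 3 cannot be told apart on this read-out. The earlier step exchanged one halogen-bearing phenyl for another, whereas here a single chlorine atom gives way to a nitro group of three heavy atoms with two hydrogen-bond acceptors, and the numbers still show no step beyond the scatter. Nothing available here offers a measured explanation for this result.

The compounds shown leave open whether a different kind of group on this aromatic carbon, such as an amine or a carboxylic acid, would also give a number that cannot be told apart from those of compound 2 and compound 3. They also leave open whether a change to the shared core itself, rather than to the group on its aryl ring, would produce a step beyond the scatter at the one concentration tested.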